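Nitrophenyl for dimethoxyphenyl on the saturated ring carbon

This account rests on a few compounds, and the source may have more. Where it says the series, first, only, none or still open, it means among the compounds named here.

The series shares one core and varies the aryl group on the (3-chlorobenzyl)sulfanyl side or the group on the saturated ring carbon. Compound 1 `COc1ccc(C2N=C(SCc3cccc(Cl)c3)NC(C)=C2C(=O)Nc2ccc(F)cc2)cc1OC` is the reference; in a functional assay on the whole organism (artery, strain albino) with Rattus norvegicus as the target, with a stated time of 180 min, at a dose of 10 mg/kg by the oral route (on this read-out higher numbers stand for more inhibition at the one dose given (going by the name of the read-out) and lower numbers for less inhibition), compound 1 gives 13.4%. Compound 2 `COc1ccc(C2N=C(SCc3ccc(Cl)cc3)NC(C)=C2C(=O)Nc2ccc(F)cc2)cc1OC` gives 20.1%, and compound 3 `COc1ccc(C2N=C(SCc3ccc(F)cc3)NC(C)=C2C(=O)Nc2ccc(F)cc2)cc1OC` gives 22.2%. The steps of a number 6.7 percentage points higher from compound 1 to compound 2 (within the scatter) and a number 8.8 percentage points higher from compound 1 to compound 3 (within the scatter) both lie within the scatter, as does a number 2.1 percentage points higher from compound 2 to compound 3 (within the scatter), so the three measured numbers cannot be told apart, and compound 1 sits among them rather than apart from them.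

Compound 4 `CC1=C(C(=O)Nc2ccc(F)cc2)C(c2ccc([N+](=O)[O-])cc2)N=C(SCc2cccc(Cl)c2)N1` differs from compound 1 by 4-nitrophenyl in place of 3,4-dimethoxyphenyl on a saturated ring carbon. Going by the values given here, no measured pair changes the group on the saturated ring carbon; the three measured steps all concern the aryl on the sulfur-bound chain carbon and therefore give no guide of their own to this change. The only anchor is the narrow band occupied by compounds 1 to 3, all of which agree within the scatter.

For compound 4 the estimate is 16%, with an expected range from 4% to 32%. The expected step is a number 2.6 percentage points higher from compound 1 to compound 4 (within the scatter), which would leave compound 4 within the scatter of the measured set.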

Compound 4, a percentage reported as inhibition, in the whole organism at one dose (the size of the read-out at that dose, not a potency): 11.9%
Compound 4: middle estimate off by 4.1 percentage points, on the high side, within the range that was stated.
By their numbers in this assay, from the lowest: compounds 4, 1, 2 and 3 (each within the scatter of the next, the first and the last beyond it).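

The position on the saturated ring carbon now has a measured pair of its own: in this assay, 4-nitrophenyl in place of 3,4-dimethoxyphenyl gives a number 1.5 percentage points lower from compound 1 to compound 4 (within the scatter). At this one oral dose, the read-out therefore does not separate these two aryl groups, so the swap on the ring carbon is as indistinguishable as the earlier swaps on the sulfur-bound chain carbon. Nothing available explains why the two aryl groups read alike.

Still open, from the compounds shown here alone, is whether a non-aryl group at this position, such as a short alkyl chain, or a phenyl ring bearing an amine or a carboxylic acid, would move clear of compound 1. Also open, going by these compounds, is whether the 4-nitrophenyl group would read the same alongside the 4-fluorobenzyl sulfanyl group of compound 3.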